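Uracil-bearing lactones: a triazinone analogue of compound 1

A few compounds are considered here, and "the series" means these few. Any claim that something is new, unique, unknown or untested is made for them only; others in the source may bear on it.

Measured so far in a functional assay on HeLa cells (Homo sapiens) for inhibition, read by MTT assay, with a stated time of 72 h; on this read-out lower numbers stand for stronger inhibition and higher numbers for weaker inhibition:
- compound 1 `O=C1O/C(=C\Cn2c(=O)[nH]c(=O)[nH]c2=O)C(OCc2ccccc2)=C1OCc1ccccc1`: > 100000 nM, a limit of the assay
- compound 2 `NC1(CCn2ccc(=O)[nH]c2=O)OC(=O)C(OCc2ccccc2)=C1OCc1ccccc1`: > 100000 nM, a limit
- compound 3 `Cc1cn(CCC2(N)OC(=O)C(OCc3ccccc3)=C2OCc2ccccc2)c(=O)[nH]c1=O`: > 100000 nM, a limit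

Compound 1 stands at the limit of > 100000 nM in this assay, at which 3 of the 3 values shown sit, so no number is known for it. Within the data shown here, the one single-point step recorded, a step that the two limits leave unreadable from compound 2 to compound 3, cannot be read either, since both ends are limits. Compound 4 `Nc1ncn(C/C=C2\OC(=O)C(OCc3ccccc3)=C2OCc2ccccc2)c(=O)n1` differs from compound 1 by a group of 8 heavy atoms (3 carbon, 4 nitrogen, 1 oxygen; one six-membered aromatic ring with 3 hetero atoms) in place of a group of 9 heavy atoms (3 carbon, 3 nitrogen, 3 oxygen; one six-membered aromatic ring with 3 hetero atoms), on a saturated chain carbon bound to a double-bonded chain carbon. Among the measured compounds shown here, no measured step bears on this change, and the shared core gives only limits so far. Compound 4 is therefore expected to stay near the limit as well, an estimated step that the limit leaves unreadable from compound 1 to compound 4, with an estimate of 150000 nM in the range 50000 nM to 500000 nM.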

Compound 4, half-maximal inhibitory concentration: 5910 nM
For compound 4 the middle estimate is 25-fold (1.40 log units) above the measured one; the measured number lies below the stated range.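

In this assay, among these compounds, the exchange of ring groups on a saturated chain carbon bound to a double-bonded chain carbon gives the only readable step, an at least 16-fold lower number from compound 1 to compound 4 (1.22 log units; beyond the scatter). This place on the shared core therefore responds to the choice of six-membered aromatic ring with 3 hetero atoms. Compound 4 alone has left the limit: the limit of > 100000 nM in this assay, at which 3 of the 4 values shown sit.

The step between the two other limit compounds cannot be read, and the data do not show which part of the entering group accounts for the drop. As far as these compounds go, whether a carboxylic acid on that ring, or a longer chain at this place, would keep the number off the limit stays open.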